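The source may hold more compounds than are shown below. What is called first, only, known or untested is meant among the compounds shown, and "the series" means these compounds.

Compound 1 `C[Se]/C(=N\C(=O)c1cccs1)NC(=O)c1cccs1` gives > 100000 nM in a functional assay on K562 cells (Homo sapiens) for cytotoxicity, read by MTT assay, with a stated time of 72 h (a higher number here means that more compound is tolerated, a lower number that less compound is tolerated), a limit of the assay and not a number. Compound 2 `CS/C(=N\C(=O)c1cccs1)NC(=O)c1cccs1` gives > 100000 nM in this assay, likewise a limit. For the measured compounds named here, compound 3 `C[Se]/C(=N\C(=O)c1cnc2ccccc2c1)NC(=O)c1cnc2ccccc2c1` gives 74800 nM in this assay, the only number among the three.

The change a group of 2 heavy atoms (1 carbon, 1 sulfur; no ring) in place of a group of 2 heavy atoms (1 carbon, 1 selenium; no ring), on a carbon with a double bond to nitrogen gives a step that the two limits leave unreadable from compound 1 to compound 2, which cannot be read because of the limit of > 100000 nM in this assay, at which 2 of the 3 values shown sit. The difference between the core of compound 1 and the core of compound 3 is not broken down here. Compound 4 `CS/C(=N\C(=O)c1cnc2ccccc2c1)NC(=O)c1cnc2ccccc2c1` carries the same change as compound 2, namely (a group of 2 heavy atoms (1 carbon, 1 sulfur; no ring) in place of a group of 2 heavy atoms (1 carbon, 1 selenium; no ring), on a carbon with a double bond to nitrogen), made on the core of compound 3.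

Since the earlier step gives no readable size, the step from compound 3 to compound 4 is expected to be small, a 1.1-fold higher number from compound 3 to compound 4 (0.03 log units; within the scatter), resting only on the value of compound 3, 74800 nM. Compound 4 is estimated at 80000 nM, with a range from 30000 nM to 200000 nM.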

Compound 4, concentration lethal to 50% of the cells: > 100000 nM
Compound 4: no number, only a limit; the forecaster's own chance of this, stated with the estimate: 35%; at least 1.2-fold (0.09 log units) between middle value and limit.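

On the core of compound 3, putting methylsulfanyl in place of the selenium-bearing group gives an at least 1.3-fold higher number from compound 3 to compound 4 (0.12 log units; that floor lies within the scatter) in this assay. On these data alone, that step rests on a limit of the assay for compound 4, so it shows only a floor, and its true size stays unknown. The steps on both cores cannot be read in size, so nothing shows whether the change carries over from one core to the other with the same effect: the limit of > 100000 nM in this assay, at which 3 of the 4 values shown sit.

The compounds shown leave open how an amine or a longer sulfur-bearing chain would read in this assay on a carbon with a double bond to nitrogen. They also leave open whether any core gives numbers for both partners of this change.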